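A few compounds are considered here, and "the series" means these few. Any claim that something is new, unique, unknown or untested is made for them only; others in the source may bear on it.

Compound 1, `Cc1ccc(CNc2ncnc3c2ncn3[C@@H]2O[C@H](CO)[C@@H](O)[C@H]2O)cc1`, is one of three nucleoside analogues examined in a functional assay on G-361 cells (Homo sapiens) for antiproliferative activity, with a stated time of 72 h (on this read-out lower numbers stand for stronger inhibition and higher numbers for weaker inhibition), where compound 1 gives "not determined" (no result reported). For compound 1 no single number was reported in this assay, and the same holds for compound 3, `COc1cccc(CNc2ncnc3c2ncn3[C@@H]2O[C@H](CO)[C@@H](O)[C@H]2O)c1OC`, for which this assay gives "not determined" (no result reported), so that compound 1 cannot be placed above or below any companion on this read-out. Among the measured compounds shown here, the only measured entry is compound 2, `OC[C@H]1O[C@@H](n2cnc3c(NCc4ccc(Cl)cc4Cl)ncnc32)[C@H](O)[C@@H]1O`, which in this assay gives 128000 nM, a weak result. The unmeasured compound 4, `OC[C@H]1O[C@@H](n2cnc3c(NCc4ccccc4OC(F)F)ncnc32)[C@H](O)[C@@H]1O`, carries a different aromatic group on the side chain: 2-(difluoromethoxy)phenyl in place of 4-methylphenyl on a saturated chain carbon bound to a nitrogen on an aromatic ring. For the measured compounds named here, since no step between measured compounds exists, the size of the change from compound 1 to compound 4 in this assay cannot be read from a measured pair; with compound 2 the only anchor, no step beyond the scatter is expected, and compound 4 is expected to remain a weak inhibitor much like compound 2 with its 128000 nM. Compound 4 is therefore estimated to give about 100000 nM in this assay, within a range from 30000 nM to 300000 nM, with a real chance that only a limit is reported.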

Compound 4, half-maximal inhibitory concentration: > 166000 nM
Compound 4 ended at the assay's limit; the forecaster's own chance of this, stated with the estimate: 40%; middle value at least 1.6-fold (0.22 log units) away from the limit.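

Compound 4 adds a second aromatic group with a readable outcome at this place, on a saturated chain carbon bound to a nitrogen on an aromatic ring, and in this assay compound 4 gives > 166000 nM, which is a limit and not a number. With 2-(difluoromethoxy)phenyl in place of 2,4-dichlorophenyl, the result is an at least 1.2-fold higher number from compound 2 to compound 4 (0.11 log units; that floor lies within the scatter), so neither of these two groups brings strong inhibition, while the true size of the step remains unknown because the value stops at the end of the read-out: the limit of > 166000 nM in this assay, at which 1 of the 4 values shown sits.

The steps that involve compound 1 and compound 3 cannot be read, so the standing of 4-methylphenyl against either 2-(difluoromethoxy)phenyl or 2,4-dichlorophenyl remains unsettled. As far as these compounds go, it also remains open whether an aromatic group carrying an amine or a carboxylic acid, or a longer chain at this same place, would give a value inside the range of this assay.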